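Replacing a small ester arm with an acid bearing a phenyl ring

A few compounds are considered here, and "the series" means these few. Any claim that something is new, unique, unknown or untested is made for them only; others in the source may bear on it.

Of the compounds shown here, two from this study have been tested so far in a functional assay on K562 cells (Homo sapiens) for cytotoxicity, read by trypan blue exclusion, with a stated time of 96 h; on this read-out higher numbers stand for weaker inhibition and lower numbers for stronger inhibition. Compound 1, with structure `COc1ccc(CS(=O)(=O)/C=C/c2c(OC)cc(OC)cc2OC)c(N)c1`, gives 25 nM in this assay. Compound 2, with structure `COC(=O)CNc1cc(CS(=O)(=O)/C=C/c2c(OC)cc(OC)cc2OC)ccc1OC`, gives 100 nM in this assay, which is the higher of the two numbers and therefore the weaker inhibition; the gap to compound 1 lies beyond the usual scatter of repeated measurements.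

Compound 3, with structure `COc1cc(OC)c(/C=C/S(=O)(=O)Cc2ccc(OC)c(NC(C(=O)O)c3ccccc3)c2)c(OC)c1`, is not yet measured. It differs from compound 2 in one place: carboxy(phenyl)methyl in place of (methoxycarbonyl)methyl on a nitrogen on an aromatic ring. The leaving group is the smaller one; the entering group brings a carboxylic acid and a phenyl ring to the same nitrogen.

Among the compounds with values here, no measured pair in this set shows what this particular exchange does, so the expectation rests on compound 2 alone, whose value of 100 nM is the only anchor. The step from compound 2 to compound 3 is expected to be modest, a 1.5-fold higher number from compound 2 to compound 3 (0.18 log units; within the scatter), and may well fall within the scatter. Compound 3 is therefore estimated at 150 nM, with a likely range from 40 nM to 600 nM.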

Compound 3, half-maximal inhibitory concentration: 15 nM
Beside the measured number, compound 3's estimate is 10-fold (1.00 log units) above it; measured number below the stated range.
By their numbers in this assay, from the lowest: compounds 3 and 1 (each within the scatter of the next); then compound 2.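

Exchanging (methoxycarbonyl)methyl for carboxy(phenyl)methyl on a nitrogen on an aromatic ring gives a 6.7-fold lower number from compound 2 to compound 3 (0.82 log units; beyond the scatter) in this assay, a clear gain in inhibition. This shows that the group on this nitrogen strongly influences the read-out, something compound 2 alone could not reveal, and that the group can grow from 5 heavy atoms to 10 heavy atoms, taking on a six-membered aromatic ring, with no loss of inhibition in this cell assay. No measurement in hand explains why the number falls, so the gain remains an observation about these two compounds.

The change also alters two things at once, replacing the methyl ester with a carboxylic acid and adding a phenyl ring, so the shown compounds cannot say which of the two accounts for the step or whether both are needed. A carboxymethyl group, which has the acid without the phenyl ring, and a (methoxycarbonyl)(phenyl)methyl group, which has the phenyl ring without the acid, would separate the two contributions on this same nitrogen.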